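From Compound 2 to Compound 3: Adding a Methoxy Group

This account rests on a few compounds, and the source may have more. Where it says the series, first, only, none or still open, it means among the compounds named here.

Compound 1 `CC(=O)Nc1ccc(Cc2noc(CCC(=O)O)n2)cc1`: 75.3%
Compound 2 `CC(=O)Nc1ccc(Cc2noc(CCC(=O)Nc3ccccc3)n2)cc1`: 34.2%

In a functional assay on the whole organism (strain C57BL/6) for inhibition, with Mus musculus as the target, read by paw edema, with stated times of 1 h and 4 h, at a dose of 100 mg/kg by the oral route (a higher number here means more inhibition at the dose given (going by the name of the read-out), a lower number less inhibition), compound 1 gives 75.3% and compound 2 gives 34.2%, the lower of the two numbers. Among the compounds with values here, the only measured step, a number 41.1 percentage points lower from compound 1 to compound 2 (beyond the scatter), concerns the carbonyl side of the chain, not the anilino ring. Compound 3 `COc1cccc(NC(=O)CCc2nc(Cc3ccc(NC(C)=O)cc3)no2)c1` differs from compound 2 by methoxy in place of hydrogen on an aromatic carbon. Within the data shown here, no measured step touches the anilino group, so nothing sets a direction; compound 3 is therefore expected to move by a number 0.8 percentage points higher from compound 2 to compound 3 (within the scatter), nothing beyond the scatter. Compound 3 is estimated at 35%, within a range from 15% to 55%.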

Compound 3, a percentage reported as inhibition, in the whole organism at one dose (the size of the read-out at that dose, not a potency): 35.6%
The estimate for compound 3 lay 0.6 percentage points below the measured number, and the stated range covers the measured number.
By their numbers in this assay, from the lowest: compounds 2 and 3 (each within the scatter of the next); then compound 1.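

The first change made on the anilino ring, methoxy in place of hydrogen on an aromatic carbon meta to a large group, gives in this assay a number 1.4 percentage points higher from compound 2 to compound 3 (within the scatter). The carbonyl replacement remains large with the methoxy group present, with (3-methoxyphenyl)amino in place of hydroxy giving a number 39.7 percentage points lower from compound 1 to compound 3 (beyond the scatter). Nothing available explains either result.

The compounds shown leave open whether a chlorine atom or an amine on this ring would also stay within the scatter of compound 2. They also leave open how a longer chain between the carbonyl and the shared core would read.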